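Exchanging the Amino Group on Compound 2

This account rests on a few compounds, and the source may have more. Where it says the series, first, only, none or still open, it means among the compounds named here.

Compound 1 `CCCCNc1nc(N)nc2ccccc12` gives 153 nM
Compound 2 `CCCCNc1nc(N)nc2cccc(C(=O)N(C)Cc3ccccc3)c12` gives 24.8 nM

In an ADME assay on the whole organism (plasma, Rattus norvegicus, strain Sprague-Dawley) for pharmacokinetics, at a dose of 10 mg/kg by the oral route (on this read-out higher numbers stand for higher exposure at the dose given and lower numbers for lower exposure), compound 2 reads 24.8 nM and is the lower of the two measured compounds. Compound 1 reads 153 nM and stands above it by a gap beyond the usual scatter. These two numbers are all that has been measured so far, and they do not differ in one place only, so they give no direct guide to the next change.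

Compound 3 `CCCCNc1nc(N)nc2cccc(C(=O)N[C@@H](C)c3ccccc3)c12` has not yet been measured in this assay and keeps the same atoms as compound 2, joined differently. It has (1-phenylethyl)amino in place of benzyl(methyl)amino on a carbonyl carbon, and the count of that change reads (1-phenylethyl)amino in place of benzyl(methyl)amino on a carbonyl carbon (the whole of the difference). Going by the values given here, with no measured step of this kind to go on, the expectation starts from compound 2 at 24.8 nM and stays close to it. The estimated step of a 1.8-fold higher number from compound 2 to compound 3 (0.26 log units; within the scatter) is expected to be small and upward, within the scatter. For compound 3 the expected value is 45 nM (estimated range 12 nM to 170 nM).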

Compound 3, maximal plasma concentration: 239 nM
Estimate against measurement, compound 3: 5.3-fold (0.73 log units) below; measured number above the stated range.
By their numbers in this assay, from the lowest: compound 2; then compounds 1 and 3 (each within the scatter of the next).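

In this assay, exchanging benzyl(methyl)amino for (1-phenylethyl)amino on the carbonyl carbon gives a 9.6-fold higher number from compound 2 to compound 3 (0.98 log units; beyond the scatter) and so shows that exposure at this position depends strongly on how the group is built, even though both groups hold the same heavy atoms. The entering group brings a hydrogen-bond donor, the amide hydrogen, and a defined stereocentre, neither of which the leaving group has, and this single step cannot separate these two differences or assign the rise to either one. Nothing measured here accounts for the rise.

Still open, going by these compounds, is whether the other stereoisomer of the (1-phenylethyl)amino group, or a plain benzylamino group that keeps the amide hydrogen but has no stereocentre, would read nearer to compound 3 or to compound 2. On these data alone, it is also open whether the higher exposure would survive on the same carbonyl carbon with a smaller amine such as methylamino or a ring amine such as morpholine, which would show how much the phenyl ring itself contributes.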